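Compound 3 to compound 4: stability estimate

The source may report more compounds than this note shows. Statements on the series, on what has been measured and on what is new or still open speak of the compounds shown alone.

In an ADME assay on S9 fraction from liver (Rattus norvegicus) for metabolic stability, with a stated time of 1 h (a higher number here means that more of the compound is left, a lower number that less of the compound is left), compound 3 (`N#Cc1cnc(NCc2cnccc2C(F)(F)F)cc1N[C@H]1CC[C@H](O)CC1`) gives 25%. Compound 2 (`N#Cc1cnc(NCc2ccccc2C(F)(F)F)cc1N[C@H]1CC[C@@H](O)CC1`) gives 31%, which lies within the scatter of compound 3. Compound 1 (`N#Cc1cnc(NCc2cnccc2C(F)(F)F)cc1NC[C@H]1C[C@H](O)C1`) gives 61%. Compound 3 lies beyond the scatter of compound 1 on the low side. Compound 4 (`CO[C@H]1CC[C@@H](CNc2cc(NCc3cnccc3C(F)(F)F)ncc2C#N)CC1`) carries (4-methoxycyclohexyl)methyl in place of 4-hydroxycyclohexyl on a nitrogen on an aromatic ring. Going by the values given here, one measured step bears on this, the large a number 36 percentage points lower from compound 1 to compound 3 (beyond the scatter) when 4-hydroxycyclohexyl replaces (3-hydroxycyclobutyl)methyl. Among the compounds with values here, compound 4 shares a ring-methyl attachment with compound 1, but no measured compound carries a methoxy group. A moderate rise in this assay is therefore expected (a number 15 percentage points higher from compound 3 to compound 4 (beyond the scatter)). Compound 4 is estimated at 40% (20% to 65%).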

Compound 4, percent of the compound remaining: 2%
Compound 4: the middle estimate sits 38 percentage points above what was measured; measured number outside the range, below it.
By their numbers in this assay, from the lowest: compound 4; then compounds 3 and 2 (each within the scatter of the next); then compound 1.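

In this assay, the attachment through a saturated chain carbon bound to a nitrogen on an aromatic ring does not by itself keep the number high: with 4-methoxycyclohexyl in place of 3-hydroxycyclobutyl there is a number 59 percentage points lower from compound 1 to compound 4 (beyond the scatter) on that same attachment. The change from 4-hydroxycyclohexyl to (4-methoxycyclohexyl)methyl gives a number 23 percentage points lower from compound 3 to compound 4 (beyond the scatter) in this series, so adding the chain carbon and losing the hydrogen-bond donor together do not recover stability here.

A (4-hydroxycyclohexyl)methyl group on the same nitrogen would separate the methoxy group from the added chain carbon. Which part of the change carries the fall stays open, and nothing at hand speaks to a cause.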